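Amide-nitrogen substituent change in a fused lactam series

The compounds below may be only part of what the source reports. "The series", "measured", "known", "first", "only" and "open" are said of these compounds alone.

Compound 1 `O=C1COc2ccc(-c3cccc(NS(=O)(=O)c4ccc(F)cc4)c3)cc2N1C1CC1` carries a cyclopropyl on the amide-type nitrogen of its shared core. In a functional assay on MCF7 cells (Homo sapiens) for antiproliferative activity, read by MTT assay, with a stated time of 72 h (a lower number here means a stronger inhibitor, a higher number a weaker inhibitor), compound 1 gives > 40000 nM, which is a limit of the assay and not a number. Among the compounds with values here, compound 2 `COc1ccc(N2C(=O)COc3ccc(-c4cnc5ccccc5c4)cc32)cc1`, with a different substituent on the same nitrogen and a different aryl group, is the only other compound measured. In this assay compound 2 gives > 40000 nM, again a limit and not a number. Where compound 1 stands is therefore only bounded: the limit of > 40000 nM in this assay, at which 2 of the 2 values shown sit, so no measurable potency is seen for either compound, and no step between measured compounds exists to read a direction from.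

Compound 3 `O=C1COc2ccc(-c3cccc(NS(=O)(=O)c4ccc(F)cc4)c3)cc2N1c1ccccc1` is not yet measured in this assay. It differs from compound 1 by phenyl in place of cyclopropyl on an amide-type nitrogen in a ring. With both known values sitting at the limit, nothing in the series points to a gain or a loss from this change. Compound 3 is expected to give 40000 nM, within 8000 nM to 100000 nM, most likely reported again as a limit. The expected step is a number no higher from compound 1 to compound 3 (the limit leaves the size open), none beyond the scatter.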

Compound 3, half-maximal inhibitory concentration: > 40000 nM
Compound 3 ended at the assay's limit (the forecaster's own chance of this, stated with the estimate: 75%); the middle value lies on the limit itself.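

Phenyl in place of cyclopropyl on the amide-type nitrogen gives no readable step between compound 1 and compound 3, because each result is a limit of the assay and not a number: the limit of > 40000 nM in this assay, at which 3 of the 3 values shown sit.

The compounds shown leave open whether either substituent on this nitrogen affects antiproliferative potency once values fall within the measurable range.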